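The source may hold more compounds than are shown below. What is called first, only, known or untested is meant among the compounds shown, and "the series" means these compounds.

Measured compounds:
compound 1 `c1ccc(C2=NN(C3=NC(c4ccccc4)CS3)C(c3cccc4ccccc34)C2)cc1` gives 5320 nM
compound 2 `c1ccc(C2=NN(C3=NC(c4ccccc4)CS3)C(c3ccc4ccccc4c3)C2)cc1` gives 3860 nM

Both were tested in a functional assay on HeLa cells (Homo sapiens) for inhibition, read by CCK-8 assay, with a stated time of 48 h; on this read-out lower numbers stand for stronger inhibition and higher numbers for weaker inhibition. Compound 1 and compound 2 share one core and differ only in the bicyclic aromatic group attached to a saturated ring carbon; the step of a 1.4-fold lower number from compound 1 to compound 2 (0.14 log units; within the scatter) is small, so the two numbers cannot be told apart, and neither compound can be called the stronger.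

Compound 3 `Clc1ccc(C2=NN(C3=NC(c4ccccc4)CS3)C(c3ccc4ccccc4c3)C2)cc1` has not yet been measured. It differs from compound 2 by chloro in place of hydrogen on an aromatic carbon. Going by the values given here, none of the measured steps touches this part of the molecule: the only step known concerns the bicyclic aromatic group on the saturated carbon, not the phenyl ring that is changed here. There is therefore no measured basis for predicting a shift in either direction, and the expectation is a step no larger than the scatter.

On that basis, compound 3 is estimated at 3500 nM, with a range from 1500 nM to 8000 nM, which corresponds to an expected step of a 1.1-fold lower number from compound 2 to compound 3 (0.04 log units; within the scatter).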

Compound 3, half-maximal inhibitory concentration: 7560 nM
Estimate against measurement, compound 3: 2.2-fold (0.33 log units) below; the range from low to high includes it.
By their numbers in this assay, from the lowest: compounds 2, 1 and 3 (each within the scatter of the next).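

Compound 1 and compound 2 carry the same unsubstituted phenyl group at this place, so compound 3 is the only one here that shows what a change on that ring does. In this assay, going from phenyl to 4-chlorophenyl gives a 2.0-fold higher number from compound 2 to compound 3 (0.29 log units; within the scatter), and this step lies within the scatter, so the number does not show that one chlorine on this aromatic carbon, para to a large group, either strengthens or weakens inhibition. No measurement is available that could explain this result.

A single chloro cannot show whether this ring position matters for inhibition of these cells, and an amine, a carboxylic acid or a methoxy group in the place of chloro might or might not give a clearly different number. As far as these compounds go, it also remains open whether chloro would give a similar result on the other phenyl group of the shared core, or alongside the naphthalen-1-yl group of compound 1.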